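This account rests on a few compounds, and the source may have more. Where it says the series, first, only, none or still open, it means among the compounds named here.

Among the compounds with values here, in a physicochemical assay for solubility, read by mass spectrometry, in phosphate buffer, with a stated time of 24 h, at pH 7.4 (on this read-out lower numbers stand for lower solubility and higher numbers for higher solubility), compound 1 (`O=C(Nc1ccc(OC(F)(F)F)cc1)NC1CCN(C(=O)C2CCOCC2)CC1`) gives 91 ug/mL, the highest of the three numbers measured so far. Compound 2 (`O=C(Nc1ccc(C(F)(F)F)c(F)c1)NC1CCN(C(=O)C2CC2)CC1`) gives 0.46 ug/mL and compound 3 (`CCOC(=O)N1CCC(NC(=O)Nc2ccc(OC(F)(F)F)c(F)c2)CC1`) gives 0.35 ug/mL. Both stand far below compound 1, beyond the scatter, while those two values lie within the scatter of each other.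

Compound 4 (`Cc1ccoc1C(=O)N1CCC(NC(=O)Nc2ccc(OC(F)(F)F)cc2)CC1`) keeps the core of compound 1 and differs from it in one place: 3-methylfuran-2-yl in place of oxan-4-yl on a carbonyl carbon. In words, 3-methylfuran-2-yl stands in place of oxan-4-yl on a carbonyl carbon.

Within the data shown here, no measured pair in this assay differs in one place only, so the data give no direct size for this step. Compounds 2 and 3 each differ from compound 1 in more than one place, which makes them only loose guides. Even so, compound 1 at 91 ug/mL is the only measured compound that carries oxan-4-yl, and compound 2 at 0.46 ug/mL and compound 3 at 0.35 ug/mL both lack it. A fall beyond the scatter is therefore expected, though a smaller one than those gaps show. The expected step is a 9.1-fold lower number from compound 1 to compound 4 (0.96 log units; beyond the scatter). Compound 4 is estimated at 10 ug/mL, with an expected range from 1.5 ug/mL to 60 ug/mL.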

Compound 4, solubility: 0.92 ug/mL
Compound 4: middle estimate off by 11-fold (1.04 log units), on the high side; measured number below the stated range.
By their numbers in this assay, from the lowest: compounds 3, 2 and 4 (each within the scatter of the next, the first and the last beyond it); then compound 1.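

In this assay the step gives the first direct size for this position: with the rest of compound 1 unchanged, 3-methylfuran-2-yl in place of oxan-4-yl on a carbonyl carbon brings a 99-fold lower number from compound 1 to compound 4 (2.00 log units; beyond the scatter) in a single change. Both groups count the same heavy atoms, carbon and oxygen, the same hydrogen-bond donors and acceptors and no net charge, and they differ in that a six-membered non-aromatic ring gives way to a five-membered aromatic ring, so these counts alone do not follow the read-out in this pair. Nothing shown bears on why the number falls, and no cause can be given for it.

This one pair does not separate the loss of oxan-4-yl from the arrival of 3-methylfuran-2-yl, nor does it tell what the methyl group on that ring contributes. From the compounds shown here alone, how furan-2-yl without the methyl, an amine such as piperidin-4-yl or an open chain such as 2-methoxyethyl would read on the same carbonyl carbon remains open.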